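Side-chain amine swap at the limit of the assay

The source may report more compounds than this note shows. Statements on the series, on what has been measured and on what is new or still open speak of the compounds shown alone.

In a functional assay on A549 cells (Homo sapiens) for antiproliferative activity, read by MTT assay, with a stated time of 48 h (on this read-out lower numbers stand for stronger inhibition and higher numbers for weaker inhibition), compound 1 (`N#Cc1nc2c(-c3nc4ccccc4[nH]3)c(N)n(CCN3CCCC3)c2nc1C#N`) gives > 50000 nM as a limit and not a number.

Compound 2 (`N#Cc1nc2c(-c3nc4ccccc4[nH]3)c(N)n(CCCO)c2nc1C#N`) gives > 50000 nM as a limit too, so its standing is known only as that limit, and the limit of > 50000 nM in this assay, at which 2 of the 2 values shown sit, applies to both compounds.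

Among the measured compounds shown here, the one measured step, a step that the two limits leave unreadable from compound 1 to compound 2, therefore offers no size to carry forward.

Compound 3 (`N#Cc1nc2c(-c3nc4ccccc4[nH]3)c(N)n(CCCN3CCCCC3)c2nc1C#N`) differs from compound 2 by piperidin-1-yl in place of hydroxy on a saturated chain carbon, three bonds along the chain from an aromatic nitrogen, turning 3-hydroxypropyl into 3-(piperidin-1-yl)propyl.

Compound 1 already carries pyrrolidin-1-yl on its chain and shows only the limit > 50000 nM in this assay, so no gain in inhibition is expected from a ring amine on the chain.

The expected step is a number no higher from compound 2 to compound 3 (the limit leaves the size open), and another reported limit is the likeliest outcome.

The estimated value for compound 3 is 50000 nM, with an expected range from 15000 nM to 100000 nM.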

Compound 3, half-maximal inhibitory concentration: 6110 nM
For compound 3 the middle estimate is 8.2-fold (0.91 log units) above the measured one; measured number outside the range, below it.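

In this assay, piperidin-1-yl in place of hydroxy on a saturated chain carbon, three bonds along the chain from an aromatic nitrogen, gives an at least 8.1-fold lower number from compound 2 to compound 3 (0.91 log units; beyond the scatter) and shows that this side chain can move the read-out off its limit. A ring amine on the chain does not by itself give that result, since compound 1 also carries one, and the change to (piperidin-1-yl)methyl gives an at least 8.1-fold lower number from compound 1 to compound 3 (0.91 log units; beyond the scatter) in this assay. Compound 3 alone has a readable number, while compound 1 and compound 2 remain limits: the limit of > 50000 nM in this assay, at which 2 of the 3 values shown sit.

The compounds shown leave open whether ring size or chain length drives the step to compound 3, a question that 3-(pyrrolidin-1-yl)propyl and 2-(piperidin-1-yl)ethyl would separate. On these data alone, how an open-chain amine such as dimethylamino, or a longer chain, would read in this assay also remains open.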